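Exchanging the Saturated Amine Ring Between Compound 2 and Compound 3

The compounds below may be only part of what the source reports. "The series", "measured", "known", "first", "only" and "open" are said of these compounds alone.

In a functional assay on HCT-116 cells (Homo sapiens) for inhibition, read by MTT assay, with a stated time of 72 h, tested at 20 uM (a lower number here means less inhibition, a higher number more inhibition at the concentration tested (going by the name of the read-out)), compound 2 `CN(c1ccc(Oc2ncnc3ccsc23)cc1)c1nccc(N2CCCCC2)n1` gives 66.2%, and it sits alongside compound 1 `CN(c1ccc(Oc2ncnc3ccsc23)cc1)c1nccc(N2CCCC2)n1`, which in this assay gives 63.6%; the step of a number 2.6 percentage points higher from compound 1 to compound 2 (within the scatter) lies within the scatter, so the two compounds cannot be told apart on these numbers. Compound 3 `CN(c1ccc(Oc2ncnc3ccsc23)cc1)c1nccc(N2CCc3ccccc32)n1` differs from compound 2 by 2,3-dihydro-1H-indol-1-yl in place of piperidin-1-yl on an aromatic carbon. Among the compounds with values here, the only measured step that bears on this change is a number 2.6 percentage points higher from compound 1 to compound 2 (within the scatter), which also swapped one saturated nitrogen ring for another at the same aromatic carbon and stayed within the scatter. Within the data shown here, no measured step introduces an aromatic ring at this position, so the expectation rests on that single flat step. Compound 3 is therefore expected to show no change beyond the scatter, a step of a number 1.2 percentage points lower from compound 2 to compound 3 (within the scatter). The estimate for compound 3 in this assay is 65%, with a range from 45% to 85%.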

Compound 3, a percentage reported as inhibition, at one concentration (the size of the read-out at that concentration, not a potency): 57.8%
Estimate against measurement, compound 3: 7.2 percentage points above, and the stated range covers the measured number.
By their numbers in this assay, from the lowest: compounds 3, 1 and 2 (each within the scatter of the next).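

In this assay, 2,3-dihydro-1H-indol-1-yl, which brings a six-membered aromatic ring of carbon only, gives a number 8.4 percentage points lower from compound 2 to compound 3 (within the scatter) and a number 5.8 percentage points lower from compound 1 to compound 3 (within the scatter). The earlier compounds had shown only an exchange of one saturated nitrogen ring for another at this aromatic carbon, whereas these steps extend the reading to a group with an aromatic ring: all three compounds remain within the scatter of one another, so the numbers do not separate them. Nothing shown gives a reason for these numbers.

On these data alone, it remains open whether morpholin-4-yl or an open-chain dimethylamino group on this carbon would also stay within the scatter. A reading at one concentration also leaves open whether the three compounds differ in potency.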